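The source may report more compounds than this note shows. Statements on the series, on what has been measured and on what is new or still open speak of the compounds shown alone.

Measured so far in a functional assay on SR cells (Homo sapiens) for inhibition, read by sulforhodamine B assay, with a stated time of 48 h; a higher number here means that more compound is tolerated, a lower number that less compound is tolerated:

- compound 1, `O=C(Nc1cccc(-n2cc(-c3ccncc3)c(-c3ccc(Cl)c(O)c3)n2)c1)Nc1ccc(Cl)c(Cl)c1`: > 32500 nM
- compound 2, `COc1cc(-c2nn(-c3cccc(NC(=O)c4cccc(C(F)(F)F)c4)c3)cc2-c2ccncc2)ccc1Cl`: > 50000 nM
- compound 3, `COc1cc(-c2nn(-c3cccc(NC(=O)Nc4ccc(Cl)c(C(F)(F)F)c4)c3)cc2-c2ccncc2)ccc1Cl`: > 32500 nM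

All three values are limits of this assay, not numbers. For compound 1 the value > 32500 nM is a limit. For compound 2 the value > 50000 nM is a limit. For compound 3 the value > 32500 nM is a limit. Compound 2 therefore stands only at a limit, as do the two other values shown; the step that the two limits leave unreadable from compound 2 to compound 3 cannot be read, since both ends sit at limits (the limit of > 32500 nM in this assay, at which 2 of the 3 values shown sit, (the limit of > 50000 nM in this assay, at which 1 of the 3 values shown sits)).

Compound 4, `COc1cc(-c2nn(-c3cccc(NC(=O)c4ccccc4)c3)cc2-c2ccncc2)ccc1Cl`, is not yet measured in this assay. Relative to compound 2 the change is hydrogen in place of trifluoromethyl on an aromatic carbon.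

No measured step bears on this change beyond the unreadable one above, so no direction can be drawn from the data; the three compounds shown all sit at limits, and nothing indicates that compound 4 should move off one. Compound 4 is expected to give about 50000 nM (range 20000 nM to 100000 nM), most likely again as a limit, corresponding to an estimated step of a number no higher from compound 2 to compound 4 (the limit leaves the size open).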

Compound 4, concentration lethal to 50% of the cells: > 100000 nM
Compound 4 was reported as a limit; the forecaster's own chance of this, stated with the estimate: 80%; at least 2.0-fold (0.30 log units) between middle value and limit.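

In this assay compound 4 gives > 100000 nM, which is a limit. Compound 2 and compound 3 also sit at limits, so neither step to compound 4 can be read. The compounds shown leave open whether hydrogen in place of trifluoromethyl changes the read-out at all.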